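Moving a Methoxy Group Across the Shared Core

The source may report more compounds than this note shows. Statements on the series, on what has been measured and on what is new or still open speak of the compounds shown alone.

Measured so far in a functional assay on HeLa cells (Homo sapiens) for cytotoxicity, read by MTT assay, with a stated time of 48 h; a lower number here means a stronger inhibitor, a higher number a weaker inhibitor:
Compound 1, `CCOC(=O)c1c(-c2cc3ccccc3oc2=O)nn(-c2cccc(C)c2)c1C(=O)OCC`: 245000 nM
Compound 2, `CCOC(=O)c1c(-c2cc3ccccc3oc2=O)nn(-c2ccc(Br)cc2)c1C(=O)OCC`: 250000 nM
Compound 3, `CCOC(=O)c1c(-c2cc3cc(OC)ccc3oc2=O)nn(-c2cccc(C)c2)c1C(=O)OCC`: 155000 nM

Among these three numbers, compound 1 stands second highest. Its nearest neighbour is compound 2, reached by a 1.0-fold higher number from compound 1 to compound 2 (0.01 log units; within the scatter). The furthest is compound 3, reached by a 1.6-fold lower number from compound 1 to compound 3 (0.20 log units; within the scatter). Both of those gaps sit inside the ordinary scatter of this assay, so the three compounds cannot be told apart by their numbers.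

Compound 4, `CCOC(=O)c1c(-c2cc3ccc(OC)cc3oc2=O)nn(-c2cccc(C)c2)c1C(=O)OCC`, has not yet been measured. Its difference from compound 1 is methoxy in place of hydrogen on an aromatic carbon. Going by the values given here, the only measured step that bears on this change is the one from compound 1 to compound 3, which also added a methoxy group to the shared core, though at a different aromatic carbon; that step was a 1.6-fold lower number from compound 1 to compound 3 (0.20 log units; within the scatter), within the scatter. The step from compound 1 to compound 2 shows that swapping the group on the aromatic nitrogen likewise left the number unchanged. On that basis no step beyond the scatter is expected in this assay, and the expected step is a 1.2-fold lower number from compound 1 to compound 4 (0.09 log units; within the scatter). Compound 4 is therefore estimated at 200000 nM, with a range from 100000 nM to 400000 nM.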

Compound 4, half-maximal inhibitory concentration: 35000 nM
Compound 4: the middle estimate sits 5.7-fold (0.76 log units) above what was measured; the measured number lies below the stated range.
By their numbers in this assay, from the lowest: compound 4; then compounds 3, 1 and 2 (each within the scatter of the next).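

In this assay the new result is a 7.0-fold lower number from compound 1 to compound 4 (0.85 log units; beyond the scatter) and it is the first step among these compounds to lie beyond the scatter, which shows that adding a methoxy group to the shared core can shift the number measurably. The earlier methoxy step, a 1.6-fold lower number from compound 1 to compound 3 (0.20 log units; within the scatter) and so within the scatter, put the same group on a different aromatic carbon, so for these compounds the outcome depends on which carbon carries the methoxy: compound 3 gives 155000 nM and compound 4 gives 35000 nM while both keep the 3-methylphenyl group on the aromatic nitrogen. Nothing available here explains why this carbon behaves differently.

Going by these compounds, it remains open whether a different group on the same aromatic carbon, such as a hydroxyl, an ethoxy or an amine, would give a step of similar size. On these data alone, it is also open whether the methoxy on this carbon would have the same effect with the 4-bromophenyl group of compound 2 on the aromatic nitrogen.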